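Swapping a carbamate for a benzoate on the shared core

This account rests on a few compounds, and the source may have more. Where it says the series, first, only, none or still open, it means among the compounds named here.

Measured so far:
- compound 1 `CN(CCCc1ccccc1)Cc1cn(CC(O)COC(=O)c2ccccc2)nn1`: 12%
- compound 2 `OC(COCc1ccccc1)Cn1cc(CN2CCN(c3ccccc3)CC2)nn1`: 37%
- compound 3 `CCCCNC(=O)OCC(O)Cn1cc(CN2CCN(c3ccccc3)CC2)nn1`: 11%

In an assay on nucleic acid for inhibition of Nucleic Acid, read by fluorescence, tested at 100 uM (on this read-out higher numbers stand for more inhibition at the one concentration tested (going by the name of the read-out) and lower numbers for less inhibition), compound 3 gives the lowest of the three numbers; against compound 1 the gap is within the scatter, while compound 2 stands clearly higher. Among the compounds with values here, the one step with a single change, a number 26 percentage points lower from compound 2 to compound 3 (beyond the scatter), shows the butylcarbamoyl group losing ground to benzyl. Compound 4 `O=C(OCC(O)Cn1cc(CN2CCN(c3ccccc3)CC2)nn1)c1ccccc1` carries the change (phenyl in place of butylamino on a carbonyl carbon). Within the data shown here, no measured step covers this exact swap; compound 1, which also holds a benzoyloxy group but a different amine, gives 12%. The expected step of a number 7 percentage points higher from compound 3 to compound 4 (within the scatter) is therefore small. Compound 4 is estimated at 18%, in the range 5% to 35%.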

Compound 4, a percentage reported as inhibition, at one concentration (the size of the read-out at that concentration, not a potency): 11%
The estimate for compound 4 lay 7 percentage points above the measured number; low and high end bracket the measured number.
By their numbers in this assay, from the lowest: compounds 3, 4 and 1 (each within the scatter of the next); then compound 2.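

In this assay, phenyl in place of butylamino on a carbonyl carbon gives no change at the digits printed from compound 3 to compound 4 (within the scatter) and so leaves the two groups indistinguishable here. Benzoyl in place of benzyl on an oxygen on a saturated carbon gives a number 26 percentage points lower from compound 2 to compound 4 (beyond the scatter) and matches the earlier step, a number 26 percentage points lower from compound 2 to compound 3 (beyond the scatter) in size, so both carbonyl groups on this oxygen read clearly under the benzyl group. Nothing available gives a reason for this. As far as these compounds go, whether a substituted benzyl group or a longer chain on this oxygen would reach or pass the number for compound 2 stays open.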